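The compounds below may be only part of what the source reports. "The series", "measured", "known", "first", "only" and "open" are said of these compounds alone.

Measured so far:
compound 1, `CC(C)=CC[C@@H](OC[C@H](C)O)C1=CC(=O)c2c(O)ccc(O)c2C1=O`; in a functional assay on HeLa cells (Homo sapiens) for cytotoxicity, read by MTT assay (on this read-out lower numbers stand for stronger inhibition and higher numbers for weaker inhibition), compound 1 gives 40300 nM.
compound 2, `CC[C@](C)(O)CC(=O)O[C@H](CC=C(C)C)C1=CC(=O)c2c(O)ccc(O)c2C1=O`; in this assay compound 2 gives 30200 nM.

The step of a 1.3-fold lower number from compound 1 to compound 2 (0.13 log units; within the scatter), so compound 2 and compound 1 lie within the scatter of each other in this assay and neither can be ranked against the other. Compound 3, `CCC(O)(CC)CC(=O)O[C@H](CC=C(C)C)C1=CC(=O)c2c(O)ccc(O)c2C1=O`, is not yet measured. It differs from compound 2 by 1-ethyl-1-hydroxypropyl in place of 1-hydroxy-1-methylpropyl on a saturated chain carbon bound to a carbonyl carbon. Among the compounds with values here, the only measured step, a 1.3-fold lower number from compound 1 to compound 2 (0.13 log units; within the scatter), concerns a different structural change and was itself within the scatter, so no step beyond the scatter is expected in this assay in either direction. Compound 3 is therefore estimated at 30000 nM, range 15000 nM to 60000 nM. The expected step is a 1.0-fold lower number from compound 2 to compound 3 (0.00 log units; within the scatter).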

Compound 3, half-maximal inhibitory concentration: 52000 nM
For compound 3 the middle estimate is 1.7-fold (0.24 log units) below the measured one; measured number inside the range.
By their numbers in this assay, from the lowest: compounds 2, 1 and 3 (each within the scatter of the next).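

In this assay, 1-ethyl-1-hydroxypropyl in place of 1-hydroxy-1-methylpropyl on a saturated chain carbon bound to a carbonyl carbon gives a 1.7-fold higher number from compound 2 to compound 3 (0.24 log units; within the scatter), and (2-ethyl-2-hydroxybutyl)carbonyl in place of 2-hydroxypropyl gives a 1.3-fold higher number from compound 1 to compound 3 (0.11 log units; within the scatter). Both steps lie within the scatter, so the larger group at this position is not told apart from either earlier side chain, and the three compounds remain unranked. No supporting evidence bears on this result.

Still open, going by these compounds, is whether an amine or a carboxylic acid in place of 1-ethyl-1-hydroxypropyl would give a step beyond the scatter.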